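A few compounds are considered here, and "the series" means these few. Any claim that something is new, unique, unknown or untested is made for them only; others in the source may bear on it.

Compound 1 `COc1ccc(C(=O)N2CCN(CC(=O)N3CCN(CCCc4c[nH]c5ccccc45)CC3)CC2)cc1` gives 148000 nM
Compound 2 `O=C(CN1CCN(C(=O)c2cccc(Cl)c2)CC1)N1CCN(CCCc2c[nH]c3ccccc23)CC1` gives 120000 nM
Compound 3 `COc1ccc(C(=O)N2CCN(CC(=O)N3CCN(CCCc4c[nH]c5ccc(F)cc45)CC3)CC2)cc1` gives 161000 nM

In an ADME assay on SH-SY5Y cells (Homo sapiens) for cytotoxicity, read by MTT assay, with a stated time of 72 h (a lower number here means a stronger inhibitor, a higher number a weaker inhibitor), compound 3 stands at 161000 nM and lies within the usual scatter of compound 1 and compound 2, so the three cannot be told apart. Compound 4 `O=C(CN1CCN(C(=O)c2ccccc2Br)CC1)N1CCN(CCCc2c[nH]c3ccc(F)cc23)CC1` keeps the rest of compound 3 and changes one group: 2-bromophenyl in place of 4-methoxyphenyl on a carbonyl carbon; in words, 2-bromophenyl in place of 4-methoxyphenyl on a carbonyl carbon. The closest measured change at that place is a 1.2-fold lower number from compound 1 to compound 2 (0.09 log units; within the scatter), where 3-chlorophenyl took the place of 4-methoxyphenyl. The other measured change, a 1.1-fold higher number from compound 1 to compound 3 (0.04 log units; within the scatter), concerns the fluoro group that compound 4 retains. Going by the values given here, no measured compound carries 2-bromophenyl, so the evidence is indirect. Going by compound 2 and its step of a 1.2-fold lower number from compound 1 to compound 2 (0.09 log units; within the scatter), no shift beyond the scatter is expected in this assay. The expected change is a 1.2-fold lower number from compound 3 to compound 4 (0.06 log units; within the scatter) and has no clear direction. Compound 4 is estimated at 140000 nM, with an expected range from 80000 nM to 240000 nM.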

Compound 4, half-maximal inhibitory concentration: 79100 nM
For compound 4 the middle estimate is 1.8-fold (0.25 log units) above the measured one; measured number outside the range, below it.
By their numbers in this assay, from the lowest: compounds 4, 2, 1 and 3 (each within the scatter of the next, the first and the last beyond it).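

In this assay, going by these compounds alone, the swap of 4-methoxyphenyl for 2-bromophenyl on the carbonyl carbon gives a 2.0-fold lower number from compound 3 to compound 4 (0.31 log units; beyond the scatter) and is the first change at this place to pass the usual scatter, though only modestly. The earlier swap to 3-chlorophenyl, with a 1.2-fold lower number from compound 1 to compound 2 (0.09 log units; within the scatter) on the core without fluoro, stayed within the scatter, so only now does the group on this carbonyl show that it can move the number at all. Nothing measured here accounts for this shift.

From the compounds shown here alone, with a single 2-bromophenyl compound, it remains open whether the shift belongs to the bromine or to the 2-bromo arrangement, and whether it would also appear without the fluoro group. Also open, going by these compounds, is how an amine or a carboxylic acid on this phenyl ring would read in this assay.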